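Aryl-to-Aryl Swap on the Amine Nitrogen of a Shared Core

The source may report more compounds than this note shows. Statements on the series, on what has been measured and on what is new or still open speak of the compounds shown alone.

Of the compounds shown here, three sharing one core have been measured in a functional assay on HeLa cells (Homo sapiens) for inhibition, read by sulforhodamine B assay; a lower number here means a stronger inhibitor, a higher number a weaker inhibitor. Compound 1 `O=C1C=C(NC2CCCCC2)C(=O)c2c1nc1n2[C@H]2OC[C@@H](O)[C@H]2OC1` carries a cyclohexyl group on the amine nitrogen, and in this assay compound 1 gives only a limit, > 16000 nM. Compound 3 `O=C1C=C(Nc2ccc(I)cc2)C(=O)c2c1nc1n2[C@H]2OC[C@@H](O)[C@H]2OC1` carries a 4-iodophenyl group in its place, and compound 3 gives 4070 nM. For the measured compounds named here, the step of an at least 3.9-fold lower number from compound 1 to compound 3 (0.59 log units; beyond the scatter) is the only single-site change among the measured compounds. That step rests on (the limit of > 16000 nM in this assay, at which 1 of the 3 values shown sits), which is a limit for compound 1. Compound 2 `COc1ccccc1NC1=CC(=O)c2c(nc3n2[C@H]2OC[C@@H](O)[C@H]2OC3)C1=O` bears a 2-methoxyphenyl group on the same nitrogen and gives 7460 nM, the highest of the two numbers that are not limits; its gap to compound 3 lies within the scatter, so the two are not separated.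

The unmeasured compound 4 `O=C1C(Nc2cccc(Cl)c2)=CC(=O)c2c1nc1n2[C@H]2OC[C@@H](O)[C@H]2OC1` differs from compound 2 by a single exchange: 3-chlorophenyl in place of 2-methoxyphenyl on an amine nitrogen. Going by the values given here, no measured step swaps one aryl group for another; the one measured step, from a cyclohexyl to a 4-iodophenyl group, speaks only to an aryl against a saturated ring. Among the compounds with values here, both aryl compounds measured so far sit close together, so compound 4 is expected to fall in the same region, with an expected change from compound 2 of a 1.4-fold lower number from compound 2 to compound 4 (0.13 log units; within the scatter), not beyond the scatter. Compound 4 is therefore estimated at 5500 nM, within a range from 2200 nM to 14000 nM.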

Compound 4, half-maximal inhibitory concentration: 7970 nM
The estimate for compound 4 lay 1.4-fold (0.16 log units) below the measured number; the range from low to high includes it.
By their numbers in this assay, from the lowest: compounds 3, 2 and 4 (each within the scatter of the next). At a limit, above all of these: compound 1.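

For the compounds shown here, the exchange of 2-methoxyphenyl for 3-chlorophenyl on the amine nitrogen provides the first step at this position that replaces one aryl group with another, and in this assay it reads a 1.1-fold higher number from compound 2 to compound 4 (0.03 log units; within the scatter). The earlier step set a 4-iodophenyl group against a saturated ring, whereas this one shows that two differently substituted phenyl groups are not separated in this assay, even though the methoxy oxygen, counted as a hydrogen-bond acceptor, leaves and a chlorine enters. Nothing measured here gives a cause for this result, and the one available observation concerns a limit on a different compound.

The compounds shown leave open whether any substituent on the phenyl ring can move the number beyond the scatter, since they include neither an unsubstituted phenyl group nor a phenyl group carrying an amine or a carboxylic acid. They also leave open how a benzyl group or a longer chain ending in an amine, placed on the same nitrogen, would compare with the aryl groups.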